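The source may hold more compounds than are shown below. What is called first, only, known or untested is meant among the compounds shown, and "the series" means these compounds.

Compound 1 `CS(=O)(=O)c1ccc(-c2oc3ccccc3c(=O)c2-c2cc(Cl)cc(Cl)c2)cc1` was examined in an assay on isolated protein for inhibition of prostaglandin G/H synthase 1 (Mus musculus), tested at 10 ug/mL; on this read-out higher numbers stand for more inhibition at the one concentration tested (going by the name of the read-out) and lower numbers for less inhibition. In this assay compound 1 gives < 5%, which is a limit of the assay rather than a number. Compound 2 `CS(=O)(=O)c1ccc(-c2oc3ccccc3c(=S)c2-c2ccc(F)cc2)cc1` is read in this assay as < 5%, again a limit. Compound 3 `CSc1ccc(-c2c(-c3ccc(S(N)(=O)=O)cc3)oc3ccccc3c2=O)cc1` reaches 90% in this assay. Compound 1 thus stands at the limit of < 5% in this assay, at which 2 of the 3 values shown sit. Compound 4 `Cc1ccccc1-c1c(-c2ccc(S(C)(=O)=O)cc2)oc2ccccc2c1=O` has not been measured; it carries 2-methylphenyl in place of 3,5-dichlorophenyl on an aromatic carbon. Going by the values given here, no measured pair differs in a single place, so the size of the step is open. A modest rise in this assay is expected, with compound 1 already resting at a limit. For compound 4 the expected value is 20%, between 5% and 55%. That expectation corresponds to a step of a number at least 15 percentage points higher from compound 1 to compound 4 (beyond the scatter).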

Compound 4, a percentage reported as inhibition, at one concentration (the size of the read-out at that concentration, not a potency): < 5%
Compound 4 gave a limit, no number; the forecaster's own chance of this, stated with the estimate: 40%; middle value at least 15 percentage points from the limit.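

In this assay, going by these compounds alone, compound 4 gives < 5%, a limit like that of compound 1, so no step between the two can be read. The compounds shown leave open whether any replacement of 3,5-dichlorophenyl on the shared core would lift inhibition clear of that limit.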